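A few compounds are considered here, and "the series" means these few. Any claim that something is new, unique, unknown or untested is made for them only; others in the source may bear on it.

Measured compounds:
Compound 1, `CCCc1c(COc2ccc(C(=O)CCCC(=O)O)cc2)ccc(C(C)=O)c1O`, 6.81
Compound 2, `CCCc1c(COc2ccc(C(=O)CC(C)(C)Cc3nnn[nH]3)cc2)ccc(C(C)=O)c1O`, 7.86
Compound 3, `CCCc1c(COc2ccc(C(=O)CCCCc3nnn[nH]3)cc2)ccc(C(C)=O)c1O`, 7.28

All three were tested in a functional assay on ileum (Cavia porcellus) with cysteinyl leukotriene receptor (Homo sapiens) as the target; a higher number here means a more potent compound, by a factor of ten per unit of this negative logarithm, a lower number a less potent compound. Compound 3 stands second highest of the three: compound 1 sits below it, the step being a number 0.47 log units higher from compound 1 to compound 3 (beyond the scatter), and compound 2 sits above it, the step being a number 0.58 log units lower from compound 2 to compound 3 (beyond the scatter). Compound 4, `CCCc1c(COc2ccc(C(=O)CCCCCCc3nnn[nH]3)cc2)ccc(C(C)=O)c1O`, has not yet been measured. It differs from compound 3 in one place: 2-(1H-tetrazol-5-yl)ethyl in place of 1H-tetrazol-5-yl on a saturated chain carbon, four bonds along the chain from a carbonyl carbon. In plain terms the chain between the carbonyl and the tetrazole ring grows by two carbons.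

Going by the values given here, none of the measured steps does exactly this. The step from compound 1 to compound 3 swaps an acid for a tetrazole at the same chain length, and the step from compound 2 to compound 3 moves the tetrazole one bond further out while removing two methyl groups; both are modest. Among the compounds with values here, no step lengthens the chain by two carbons with everything else held fixed, so the direction is uncertain. Compound 4 is therefore expected to sit close to compound 3, with a number 0.28 log units lower from compound 3 to compound 4 (within the scatter) as the estimated step, most likely a slight fall. The estimated value for compound 4 is 7, within a range from 6.4 to 7.6.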

Compound 4, negative logarithm of the antagonist equilibrium constant: 7.33
Compound 4: middle estimate off by 0.33 log units, on the low side, and the stated range covers the measured number.
By their numbers in this assay, from the lowest: compound 1; then compounds 3 and 4 (each within the scatter of the next); then compound 2.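

In this assay, lengthening the unbranched chain by putting 2-(1H-tetrazol-5-yl)ethyl in place of 1H-tetrazol-5-yl leaves the read-out unchanged within the usual scatter (a number 0.05 log units higher from compound 3 to compound 4 (within the scatter)), so at this place the tetrazole ring can sit further out along the chain with no measurable cost or gain across these two lengths. The advantage over the carboxylic acid of compound 1 also persists at the longer length (a number 0.52 log units higher from compound 1 to compound 4 (beyond the scatter)), which shows that it does not depend on the shorter chain of compound 3. Extra length on the unbranched chain does not match the branched chain of compound 2, however (a number 0.53 log units lower from compound 2 to compound 4 (beyond the scatter)).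

Nothing given here explains why these two chain lengths read alike, or why the branched chain reads higher. Still open, going by these compounds, are whether a longer chain such as 7-(1H-tetrazol-5-yl)heptyl would keep this level, and whether adding the two methyl groups of compound 2 to the longer chain of compound 4, or placing a carboxylic acid at its end, would raise or lower the number.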